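Compound 3 to compound 4: 4-fluorophenyl to phenyl

This account rests on a few compounds, and the source may have more. Where it says the series, first, only, none or still open, it means among the compounds named here.

In a functional assay on MCF-10A cells (Homo sapiens) for antiproliferative activity, with a stated time of 48 h (a higher number here means that more compound is needed for the effect, a lower number that less compound is needed), the three measured compounds sit close together: compound 1 (`COc1ccc2nc(C)cc(NCc3ccccc3)c2c1`) gives 25900 nM while compound 2 (`COc1ccc2nc(C)cc(NCc3cccnc3)c2c1`) gives 44800 nM and compound 3 (`COc1ccc2nc(C)cc(SCc3ccc(F)cc3)c2c1`) gives 41000 nM on the same scale. Compound 3 stands within the scatter of both other compounds, so no order can be read among the three.

The next compound is compound 4 (`COc1ccc2nc(C)cc(SCc3ccccc3)c2c1`). It differs from compound 3 by hydrogen in place of fluoro on an aromatic carbon, which turns 4-fluorophenyl into phenyl.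

Within the data shown here, no measured pair shows this change directly. Among the measured compounds shown here, the one measured step in a single place is a 1.7-fold higher number from compound 1 to compound 2 (0.24 log units; within the scatter) and it concerns pyridin-3-yl in place of phenyl, so it bears on the present change only loosely. Resting on compound 3 at 41000 nM and on that step within the scatter, no step beyond the scatter is expected in this assay and no direction can be given. The estimated change is a 1.1-fold lower number from compound 3 to compound 4 (0.03 log units; within the scatter) and it is expected to stay within the scatter. Compound 4 is expected at 38000 nM with an estimated range from 20000 nM to 70000 nM in this series.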

Compound 4, half-maximal effective concentration: 30600 nM
Compound 4: middle estimate off by 1.2-fold (0.09 log units), on the high side; low and high end bracket the measured number.
By their numbers in this assay, from the lowest: compounds 1, 4, 3 and 2 (each within the scatter of the next).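

In this assay, hydrogen in place of fluoro on an aromatic carbon, para to a large group, gives a 1.3-fold lower number from compound 3 to compound 4 (0.13 log units; within the scatter). Among these compounds, this is the first reading of this position on the six-membered aromatic ring of carbon only, and it shows that fluoro and hydrogen cannot be told apart there. The change also joins a 1.7-fold higher number from compound 1 to compound 2 (0.24 log units; within the scatter), which concerned pyridin-3-yl in place of phenyl, so both single-place steps available so far stay within the scatter, and no change at the terminal ring has yet moved the number measurably. No supporting measurement accompanies this result, and nothing can be said about what lies behind it.

The compounds shown leave open whether any group at this position can move the number beyond the scatter, since fluoro and hydrogen are the only two seen there; a carboxylic acid, an amine or a longer chain in the same place would test this. Also open, on these data alone, is whether changes elsewhere on the shared core, such as replacing the methoxy group, would separate compounds more clearly in this assay.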